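The source may report more compounds than this note shows. Statements on the series, on what has been measured and on what is new or still open speak of the compounds shown alone.

Working notes on the series, read in a functional assay on HCT-116 cells (Homo sapiens) for antiproliferative activity, read by sulforhodamine B assay, with a stated time of 72 h; a lower number here means a stronger inhibitor, a higher number a weaker inhibitor. Compound 1 (`CNC(=O)C[C@@H]1C[C@@H](c2ccc(Cl)c(Cl)c2)[C@H](NC(=O)c2cc(-c3c(Cl)cnn3C)c(Cl)o2)CN1`) gives 450 nM, compound 2 (`Cn1ncc(Cl)c1-c1cc(C(=O)N[C@@H]2CN[C@H](CC(O)CO)C[C@H]2c2ccc(Cl)c(Cl)c2)oc1Cl`) gives 1110 nM, and compound 3 (`Cn1ncc(Cl)c1-c1cc(C(=O)N[C@@H]2CN[C@H](CC(=O)NCCO)C[C@H]2c2ccc(Cl)c(Cl)c2)oc1Cl`) gives 670 nM. Compound 3 lies within the scatter of both others: a 1.5-fold higher number from compound 1 to compound 3 (0.17 log units; within the scatter), and a 1.7-fold lower number from compound 2 to compound 3 (0.22 log units; within the scatter).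

Compound 4 (`COCC[C@@H]1C[C@@H](c2ccc(Cl)c(Cl)c2)[C@H](NC(=O)c2cc(-c3c(Cl)cnn3C)c(Cl)o2)CN1`) carries methoxymethyl in place of (2-hydroxyethyl)carbamoyl on a saturated chain carbon bound to a saturated ring carbon.

Two measured steps act at this same place. One is modest, a 2.5-fold higher number from compound 1 to compound 2 (0.39 log units; beyond the scatter), and the other stays within the scatter, a 1.7-fold lower number from compound 2 to compound 3 (0.22 log units; within the scatter). Within the data shown here, neither tests methoxymethyl, which no measured compound carries, so the direction remains open and the range is kept wide. Across these three compounds, the changes have moved the number only slightly, with the step to compound 2 from compound 1 the only one beyond the scatter. No step beyond the scatter is therefore expected in this assay. The estimated step is a 1.0-fold lower number from compound 3 to compound 4 (0.01 log units; within the scatter). The expected value for compound 4 is 650 nM, with an estimated range of 250 nM to 1500 nM.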

Compound 4, half-maximal inhibitory concentration: 470 nM
For compound 4 the middle estimate is 1.4-fold (0.14 log units) above the measured one, within the range that was stated.
By their numbers in this assay, from the lowest: compounds 1, 4, 3 and 2 (each within the scatter of the next, the first and the last beyond it).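

In this assay, methoxymethyl, with no hydrogen-bond donor and no carbonyl, is accepted on a saturated chain carbon bound to a saturated ring carbon: a 1.4-fold lower number from compound 3 to compound 4 (0.15 log units; within the scatter) and a 1.0-fold higher number from compound 1 to compound 4 (0.02 log units; within the scatter) both stay within the scatter. A carbamoyl group is therefore not needed at this place for a number at this level, though this rests on compound 4 alone. Among these compounds, the one new step beyond the scatter, a 2.4-fold lower number from compound 2 to compound 4 (0.37 log units; beyond the scatter), is modest, and compound 2 stands apart only from compound 1 and compound 4, not from compound 3; no measured evidence explains these differences.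

Going by these compounds, whether a primary amine or a carboxylic acid at this place would move the number beyond the scatter remains open. Also open, on these data alone, is how a longer ether chain would read in this assay.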